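This account rests on a few compounds, and the source may have more. Where it says the series, first, only, none or still open, it means among the compounds named here.

Measured so far in a functional assay on HT-29 cells (Homo sapiens) for antiproliferative activity, read by MTT assay, with a stated time of 72 h; a lower number here means a stronger inhibitor, a higher number a weaker inhibitor:

Compound 1 `CNc1nc(-c2cc(OC)c(OC)c(OC)c2)c(-c2ccc3ccccc3c2)s1`: 38.2 nM
Compound 2 `CNc1nc(-c2cc(OC)c(OC)c(OC)c2)c(-c2ccc(OC)cc2)s1`: 6.3 nM

Only these two compounds have been measured, so the comparison is small. Compound 1 has the higher number of the pair and is therefore the weaker inhibitor, and its gap to compound 2 lies beyond the usual scatter of repeated measurements.

The next compound is compound 3 `COc1cc(-c2nc(C)sc2-c2ccc3ccccc3c2)cc(OC)c1OC`, made from compound 1 by a single change. Methyl takes the place of methylamino on an aromatic carbon of a five-membered aromatic ring with 1 nitrogen and 1 sulfur: methyl in place of methylamino on an aromatic carbon.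

Going by the values given here, both measured compounds carry methylamino, so no measured pair shows what this swap does, and any forecast is a judgement with a wide margin. The expectation here is a loss of potency beyond the scatter in this assay, meaning a higher number, with an estimated size of a 5.2-fold higher number from compound 1 to compound 3 (0.72 log units; beyond the scatter). For compound 3 the expected value is 200 nM, with an estimated range from 40 nM to 1500 nM.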

Compound 3, half-maximal inhibitory concentration: 702 nM
The estimate for compound 3 lay 3.5-fold (0.55 log units) below the measured number; measured number inside the range.
By their numbers in this assay, from the lowest: compound 2; then compound 1; then compound 3.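

Going by these compounds alone, until this result, both measured compounds carried methylamino on this aromatic carbon, so they showed nothing about how much the group matters. In this assay, methyl in place of methylamino gives an 18-fold higher number from compound 1 to compound 3 (1.26 log units; beyond the scatter) and so places this position among those where a small edit strongly changes the read-out, at least on the core of compound 1. The swap removes one heavy atom and changes the count of hydrogen-bond donors and acceptors from one each to none, but nothing measured here links the loss of potency to either difference or to any other cause.

The compounds shown leave open whether the same swap would cost as much on the core of compound 2, which carries a different large group. They also leave open how a plain amine, a hydroxyl group or dimethylamino would behave on this carbon, and such groups could help separate the role of the nitrogen from that of its hydrogen.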